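Trading dimethylamino for methyl on the shared core

A few compounds are considered here, and "the series" means these few. Any claim that something is new, unique, unknown or untested is made for them only; others in the source may bear on it.

Within the data shown here, compound 1 `C/N=C(/NC#N)NCCCCn1nc(N(C)C)ccc1=O` stands lowest of the two compounds measured so far in a functional assay on the whole organism with Rattus norvegicus as the target, at a dose of 100 mg/kg (a lower number here means less inhibition, a higher number more inhibition at the dose given (going by the name of the read-out)), where compound 1 gives 26.3%. Compound 2 `C/N=C(/NC#N)NCCCn1nc(-c2ccccc2)cc(C)c1=O` gives 42.8% in this assay, a result beyond the scatter from compound 1, though the two compounds differ in more than one place. Compound 3 `C/N=C(/NC#N)NCCCCn1nc(C)ccc1=O` has not been measured; it differs from compound 1 by methyl in place of dimethylamino on an aromatic carbon. Among the measured compounds shown here, with no single-point step recorded among the measured compounds, the change from compound 1 to compound 3 is expected to be small, a number 1.7 percentage points higher from compound 1 to compound 3 (within the scatter), within the scatter in either direction. Compound 3 is estimated at 28%, between 12% and 45%.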

Compound 3, a percentage reported as inhibition, in the whole organism at one dose (the size of the read-out at that dose, not a potency): 23.5%
Beside the measured number, compound 3's estimate is 4.5 percentage points above it; measured number inside the range.
By their numbers in this assay, from the lowest: compounds 3 and 1 (each within the scatter of the next); then compound 2.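

Among these compounds, the step of a number 2.8 percentage points lower from compound 1 to compound 3 (within the scatter) is the first comparison on the shared core in this assay that turns on a single place, and it shows that dimethylamino and methyl on this aromatic carbon cannot be told apart at this dose, even though the 3 heavy atoms and 1 hydrogen-bond acceptor of dimethylamino give way to the 1 heavy atom of methyl. Nothing available explains this result.

On these data alone, whether a carboxylic acid or a primary amine on this carbon would also stay within the scatter remains open, and so does the effect of a longer chain on the ring nitrogen.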